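A few compounds are considered here, and "the series" means these few. Any claim that something is new, unique, unknown or untested is made for them only; others in the source may bear on it.

For the measured compounds named here, in a functional assay on HCT-15 cells (Homo sapiens) for cytotoxicity, read by sulforhodamine B assay, with a stated time of 72 h (a lower number here means a stronger inhibitor of growth, a higher number a weaker inhibitor of growth), compound 1 (`O=C(Nc1cc(C(F)(F)F)cc(C(F)(F)F)c1)C1CCc2ccccc2N1C(=O)c1ccccc1Cl`) gives 4050 nM, the lowest of the three numbers measured so far. Compound 3 (`O=C(Nc1ccccc1O)C1CCc2ccccc2N1C(=O)c1ccc(Cl)cc1`) gives a higher 20200 nM, and compound 2 (`CC(=O)N1c2ccccc2CCC1C(=O)Nc1ccccc1O`) gives the highest, 54500 nM.

Compound 4 (`CCCC(=O)N1c2ccccc2CCC1C(=O)Nc1cc(C(F)(F)F)cc(C(F)(F)F)c1`) is compound 1 with one change: propyl in place of 2-chlorophenyl on a carbonyl carbon, the carbonyl that is bonded to the amide-type nitrogen in a ring (propyl in place of 2-chlorophenyl on a carbonyl carbon). The rest of the structure stays as it is.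

Going by the values given here, only one measured step bears on this change: a 2.7-fold lower number from compound 2 to compound 3 (0.43 log units; beyond the scatter). That step is modest, and it swaps a small chain for a chlorinated aromatic ring at the same kind of carbonyl. Compound 4 moves the opposite way, from an aromatic ring to a chain, so a change in the opposite direction seems the reasonable reading, toward a weaker inhibitor of growth. The evidence is thin, however. Propyl is not methyl, the chlorine sits on a differently named ring, and compound 2 and compound 3 also differ from compound 1 in the other amide group.

A modest rise is therefore expected, estimated as a 2.1-fold higher number from compound 1 to compound 4 (0.32 log units; beyond the scatter). For compound 4 the estimated value is 8500 nM, with a range from 3000 nM to 24000 nM.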

Compound 4, concentration for 50% growth inhibition: 21900 nM
Compound 4: the middle estimate sits 2.6-fold (0.41 log units) below what was measured; low and high end bracket the measured number.
By their numbers in this assay, from the lowest: compound 1; then compounds 3 and 4 (each within the scatter of the next); then compound 2.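

In this assay there is now a direct reading at this position, the carbonyl carbon bonded to the amide-type nitrogen in a ring, with the rest of compound 1 held fixed: a 5.4-fold higher number from compound 1 to compound 4 (0.73 log units; beyond the scatter). For the compounds shown here, replacing 2-chlorophenyl with propyl therefore weakens growth inhibition on this scaffold, and the step points the same way as the only earlier comparison at this kind of carbonyl, a 2.7-fold lower number from compound 2 to compound 3 (0.43 log units; beyond the scatter), where a chlorinated ring took the place of a short chain; these two pairs agree, although they differ in the chain, in the ring and in the other amide group, and neither goes against the other. No measurement of any property of these groups is available to explain the size of the new step.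

The change removes an aromatic ring and a chlorine together, so the compounds shown leave open which of the two matters, a question that a plain phenyl on this carbonyl carbon would address. They also leave open whether a longer chain such as hexyl would stay close to propyl or move toward 2-chlorophenyl.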